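The compounds below may be only part of what the source reports. "The series", "measured", "known", "first", "only" and "open" are said of these compounds alone.

Compound 1 `CCCC(=O)OCSc1ccccc1C(=O)NCC(N)=O` is the reference point of this comparison. In an ADME assay on CEM-SS cells (Homo sapiens) for cytotoxicity, read by XTT assay, with a stated time of 6 days (a lower number here means that less compound is tolerated, a higher number that more compound is tolerated), compound 1 gives > 100 uM, which is a limit of the assay rather than a number. The two measured neighbours have numbers of their own: compound 2 `CCCC(=O)OCSc1ccccc1C(=O)Nc1ccccc1C(N)=O` gives 50.1 uM in this assay, and compound 3 `CCCC(=O)OCSc1ccccc1C(=O)N(C)CC(=O)N(C)C` gives 57.3 uM. Going by the values given here, the one single-point step that has been measured runs an at least 1.7-fold lower number from compound 1 to compound 3 (0.24 log units; that floor lies within the scatter), and its floor lies within the scatter; the result for compound 1 rests on (the limit of > 100 uM in this assay, at which 1 of the 3 values shown sits). Compound 4 `CCCCCNC(=O)CNC(=O)c1ccccc1SCOC(=O)CCC` has not yet been measured. It differs from compound 1 by pentyl in place of hydrogen on an amide-type nitrogen. This resembles the measured step in that an amide nitrogen gains carbon substituents, and that step, together with the number for compound 2, points toward a somewhat lower number. The expectation for compound 4 is therefore a step of an at least 2.0-fold lower number from compound 1 to compound 4 (0.30 log units; that floor lies within the scatter), and its value in this assay is estimated at 50 uM, between 20 uM and 110 uM.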

Compound 4, half-maximal toxic concentration: 24.8 uM
For compound 4 the middle estimate is 2.0-fold (0.30 log units) above the measured one; the range from low to high includes it.
By their numbers in this assay, from the lowest: compound 4; then compounds 2 and 3 (each within the scatter of the next). At a limit, above all of these: compound 1.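

In this assay, pentyl in place of hydrogen on an amide-type nitrogen gives an at least 4.0-fold lower number from compound 1 to compound 4 (0.60 log units; beyond the scatter). This shows that a change at this nitrogen can move the number beyond the scatter, which the earlier step to compound 3, with its floor within the scatter, could not show. Compound 1 gives > 100 uM, which is a limit of the assay and not a number, so the true size of the step stays unknown and only its floor can be read: the limit of > 100 uM in this assay, at which 1 of the 4 values shown sits.

The compounds shown leave open whether a shorter chain such as ethyl or a longer chain such as octyl on this nitrogen would lower the number as far. They also leave open what a chain ending in an amine or a carboxylic acid would do here.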